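Aryl swap on the enone: outlook for compound 4

The source may hold more compounds than are shown below. What is called first, only, known or untested is meant among the compounds shown, and "the series" means these compounds.

Compound 1 `COc1ccc(/C=C/C(=O)c2ccc(OC)c3c2OC(C)(C)C=C3)c(F)c1` carries 2-fluoro-4-methoxyphenyl on a double-bonded chain carbon bound to a double-bonded chain carbon; in a functional assay on HepG2 cells (Homo sapiens) for antiproliferative activity, read by MTT assay, with a stated time of 24 h (on this read-out lower numbers stand for stronger inhibition and higher numbers for weaker inhibition), compound 1 gives 7560 nM, the highest of the three numbers in hand, although its gap to compound 3 is within the scatter. Compound 2 `COc1ccc(C(=O)/C=C/c2cccc([N+](=O)[O-])c2)c2c1C=CC(C)(C)O2` gives 2830 nM in this assay, and compound 3 `COc1ccc(C(=O)/C=C/c2ccccn2)c2c1C=CC(C)(C)O2` gives 5760 nM. The step of a 2.7-fold lower number from compound 1 to compound 2 (0.43 log units; beyond the scatter) is beyond the scatter, the step of a 1.3-fold lower number from compound 1 to compound 3 (0.12 log units; within the scatter) is not, and between the two replacements a 2.0-fold higher number from compound 2 to compound 3 (0.31 log units; beyond the scatter).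

Compound 4 `COc1ccc(C(=O)/C=C/c2cc(Cl)ccc2O)c2c1C=CC(C)(C)O2` is not yet measured. Against compound 1 the change is 5-chloro-2-hydroxyphenyl in place of 2-fluoro-4-methoxyphenyl on a double-bonded chain carbon bound to a double-bonded chain carbon. Both measured steps from compound 1 swap the same group at the same place, and both run toward lower numbers, modestly at most. For the measured compounds named here, no measured compound carries a hydrogen-bond donor at this place, so that part of the change is uncharted; the working assumption is a modest lowering of similar size. Compound 4 is therefore expected to give 4500 nM in this assay, with a range of 1500 nM to 12000 nM. The expected step of a 1.7-fold lower number from compound 1 to compound 4 (0.23 log units; within the scatter) would leave compound 4 in the band spanned by compound 2 and compound 3.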

Compound 4, half-maximal inhibitory concentration: 6640 nM
Beside the measured number, compound 4's estimate is 1.5-fold (0.17 log units) below it; the measured number falls inside the stated range.
By their numbers in this assay, from the lowest: compound 2; then compounds 3, 4 and 1 (each within the scatter of the next).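

In this assay, for the compounds shown here, 5-chloro-2-hydroxyphenyl is the first group at this place with a hydrogen-bond donor, and the step of a 1.1-fold lower number from compound 1 to compound 4 (0.06 log units; within the scatter) shows that this swap for 2-fluoro-4-methoxyphenyl leaves the number level, so a donor here gives no readable gain on this read-out. The step of a 1.2-fold higher number from compound 3 to compound 4 (0.06 log units; within the scatter) also places the new group level with pyridin-2-yl, whereas a 2.3-fold higher number from compound 2 to compound 4 (0.37 log units; beyond the scatter) sets 3-nitrophenyl apart; among the four compounds, the three groups in compound 1, compound 3 and compound 4 lie within the scatter of one another, and compound 2 alone goes against that flat picture. No measurement is at hand that would account for this flat picture or for the position of compound 2.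

The compounds shown cannot separate the chlorine from the hydroxyl within 5-chloro-2-hydroxyphenyl, since the two enter together and neither appears alone on a phenyl ring at this place. As far as these compounds go, it also remains open whether a phenyl ring bearing an amine or a carboxylic acid on a double-bonded chain carbon bound to a double-bonded chain carbon would stay in this narrow band or move past compound 2.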